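The compounds below may be only part of what the source reports. "The series", "measured", "known", "first", "only" and "open" are said of these compounds alone.

Working notes on the carbamate series. Compound 1 `CCCCOC(=O)Nc1ccc([Se]C#N)cc1` gives 63500 nM in a functional assay on CCRF-CEM cells (Homo sapiens) for cytotoxicity, read by MTT assay, with a stated time of 72 h; on this read-out higher numbers stand for lower toxicity in this test and lower numbers for higher toxicity in this test. Compound 2 `C=CCOC(=O)Nc1ccc([Se]C#N)cc1` gives 68600 nM, and the change a 1.1-fold higher number from compound 1 to compound 2 (0.03 log units; within the scatter) stays within the scatter. Compound 3 `N#C[Se]c1ccc(NC(=O)OCc2ccc([N+](=O)[O-])cc2)cc1` gives 68800 nM; compound 3 thus sits alongside compounds 1 and 2, all three within the scatter of one another. Compound 4 `N#C[Se]c1ccc(NC(=O)OCc2ccccc2)cc1` is not yet measured; it differs from compound 3 by hydrogen in place of nitro on an aromatic carbon. Among the measured compounds shown here, no measured step touches the benzyl ring, so only the indirect evidence of the carbamate-side step from compound 1 to compound 2 bears on it, and that step was within the scatter. For compound 4 the expected step of a 1.0-fold lower number from compound 3 to compound 4 (0.01 log units; within the scatter) is therefore no change beyond the scatter. Compound 4 is estimated at 68000 nM, in the range 34000 nM to 136000 nM.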

Compound 4, concentration lethal to 50% of the cells: 73700 nM
Compound 4: middle estimate off by 1.1-fold (0.03 log units), on the low side; low and high end bracket the measured number.
By their numbers in this assay, from the lowest: compounds 1, 2, 3 and 4 (each within the scatter of the next).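

In this assay, among the compounds shown here, hydrogen in place of nitro on the aromatic carbon gives a 1.1-fold higher number from compound 3 to compound 4 (0.03 log units; within the scatter) and is the first step read on the ring itself, with no shift beyond the scatter. Phenyl in place of vinyl gives a 1.1-fold higher number from compound 2 to compound 4 (0.03 log units; within the scatter) and phenyl in place of propyl gives a 1.2-fold higher number from compound 1 to compound 4 (0.06 log units; within the scatter) so the benzyl, allyl and butyl carbamates all read alike. Nothing measured here accounts for this flat picture. Open remains whether an amine or a carboxylic acid on that ring carbon, or a longer chain on the carbamate oxygen, would give a step beyond the scatter.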